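A few compounds are considered here, and "the series" means these few. Any claim that something is new, unique, unknown or untested is made for them only; others in the source may bear on it.

Values in a functional assay on MCF7 cells (Homo sapiens) for cytotoxicity, read by CellTiter-Glo, with a stated time of 5 days (on this read-out higher numbers stand for weaker inhibition and lower numbers for stronger inhibition), so far

Compound 1 `CC/C(=C(/c1ccc(/C=C/C(=O)O)cc1)c1ccc2[nH]c(=O)sc2c1)c1ccccc1` gives 158 nM
Compound 2 `CC/C(=C(/c1ccc(/C=C/C(=O)O)cc1)c1ccc2[nH]c(=O)oc2c1)c1ccccc1` gives 56 nM
Compound 3 `CC/C(=C(/c1ccc(/C=C/C(=O)O)cc1)c1ccc2[nH]ncc2c1)c1ccccc1` gives 6 nM

Compound 3 stands lowest of the three at 6 nM in this set. Compound 4 `CC/C(=C(/c1ccc(/C=C/C(=O)O)cc1)c1cccc2[nH]ncc12)c1ccccc1` is still unmeasured and carries 1H-indazol-4-yl in place of 1H-indazol-5-yl on the double-bonded chain carbon (1H-indazol-4-yl in place of 1H-indazol-5-yl on a double-bonded chain carbon bound to an aromatic carbon and a double-bonded chain carbon). Within the data shown here, no measured step moves the attachment of a group in this way. The nearest evidence is the exchange of the whole group at that place, modest in a 2.8-fold lower number from compound 1 to compound 2 (0.45 log units; beyond the scatter) and in a 9.3-fold lower number from compound 2 to compound 3 (0.97 log units; beyond the scatter) and large in a 26-fold lower number from compound 1 to compound 3 (1.42 log units; beyond the scatter) on the same read-out. Because compound 3 stands lowest at 6 nM in this assay a modest rise is expected rather than a further fall. The estimated step is (a 6.7-fold higher number from compound 3 to compound 4 (0.82 log units; beyond the scatter)). Compound 4 is expected at 40 nM (range 8 nM to 200 nM).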

Compound 4, half-maximal inhibitory concentration: 21 nM
The estimate for compound 4 lay 1.9-fold (0.28 log units) above the measured number, and the stated range covers the measured number.
By their numbers in this assay, from the lowest: compound 3; then compound 4; then compound 2; then compound 1.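

In this assay, 1H-indazol-4-yl in place of 1H-indazol-5-yl on the double-bonded chain carbon raises the number (a 3.5-fold higher number from compound 3 to compound 4 (0.54 log units; beyond the scatter)), which shows that the attachment of the group at this place matters, and not only the group itself. The moved group still retains an advantage over the groups of the two earlier compounds (a 2.7-fold lower number from compound 2 to compound 4 (0.43 log units; beyond the scatter); a 7.5-fold lower number from compound 1 to compound 4 (0.88 log units; beyond the scatter)). No measurement shown accounts for this shift. The compounds shown leave open whether a primary amide in place of the carboxylic acid would preserve these numbers with either 1H-indazol-5-yl or 1H-indazol-4-yl at this place.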